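The source may report more compounds than this note shows. Statements on the series, on what has been measured and on what is new or still open speak of the compounds shown alone.

Measured so far:
compound 1, `CCc1ccc(Nc2cc(NC(=O)Nc3cc(OC)cc(OC)c3)ncn2)cc1`: 23.5%
compound 2, `COc1ccc(Br)cc1Nc1cc(NC(=O)Nc2c(Cl)cccc2Cl)ncn1`: 45%

In a functional assay on NCI-H520 cells (Homo sapiens) for inhibition, read by MTT assay, with a stated time of 48 h, tested at 10 uM (on this read-out higher numbers stand for more inhibition at the one concentration tested (going by the name of the read-out) and lower numbers for less inhibition), compound 1 gives 23.5%, the lower of the two numbers in hand. Compound 2, which carries a different amine and a different urea aryl group, gives 45% in this assay, a number higher than that of compound 1 by a gap beyond the usual scatter. Compound 3, `COc1cc(NC(=O)Nc2cc(Nc3ccc(Br)cc3OC)ncn2)cc(OC)c1`, has not been measured. It differs from compound 1 in one place: 4-bromo-2-methoxyphenyl in place of 4-ethylphenyl on a nitrogen on an aromatic ring. The group that enters is the same amine aryl group found in compound 2, while the urea aryl group of compound 1 is kept. Since the step between compound 1 and compound 2 changes two places at once, its size cannot be assigned to either change alone. A moderate rise is nonetheless expected for compound 3, and the step of a number 11.5 percentage points higher from compound 1 to compound 3 (beyond the scatter) is estimated to lie beyond the scatter. In this assay compound 3 is expected to give about 35%, with a range from 15% to 55%.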

Compound 3, a percentage reported as inhibition, at one concentration (the size of the read-out at that concentration, not a potency): 36.1%
Compound 3: middle estimate off by 1.1 percentage points, on the low side, and the stated range covers the measured number.
By their numbers in this assay, from the lowest: compound 1; then compounds 3 and 2 (each within the scatter of the next).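

With the urea aryl group of compound 1 kept, the change from 4-ethylphenyl to 4-bromo-2-methoxyphenyl on the nitrogen alone gives a modest rise in this assay, a number 12.6 percentage points higher from compound 1 to compound 3 (beyond the scatter), so this one place accounts for part of the gap that the two-place difference between compound 1 and compound 2 could not divide. With this amine aryl group in both, compound 3 at 36.1% and compound 2 at 45% lie within the scatter of each other, and the change of urea aryl group between them gives no readable difference. No evidence at hand explains the step. On these data alone, what stays open is how a plain 4-bromophenyl or 2-methoxyphenyl group on this nitrogen would compare, and so which of the two substituents carries the rise. Also open, as far as these compounds go, is whether the rise would appear on the urea aryl group of compound 2.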